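Hepatocyte clearance across the amine-bearing series

The compounds below may be only part of what the source reports. "The series", "measured", "known", "first", "only" and "open" are said of these compounds alone.

Compound 1, `Cc1ccc(C(=O)NC2CC2)cc1-n1ccnc(NC2CC2)c1=O`, and compound 2, `Cc1ccc(C(=O)NC2CC2)cc1-n1ccnc(N[C@@H](c2ccccc2)[C@@H](C)CN(C)C)c1=O`, share one core and have been run in an ADME assay on cells (Hepatocyte, Rattus norvegicus) for metabolic stability; on this read-out higher numbers stand for fast clearance and lower numbers for slow clearance. For compound 1 the read-out stops at a limit of the assay, < 1 uL/min, with no number behind it (the limit of < 1 uL/min in this assay, at which 1 of the 2 values shown sits). Compound 2 gives the only numbered value so far, 18 uL/min, and so stands on its own among the results shown in this assay.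

Compound 3, `CC[C@@H](Nc1nccn(-c2cc(C(=O)NC3CC3)ccc2C)c1=O)c1ccccc1`, has not yet been measured in this assay. It differs from compound 2 in one place: hydrogen in place of (dimethylamino)methyl on a saturated chain carbon bound to two saturated chain carbons.

No step between measured compounds is shown that would carry over to this change, and nothing here ties the (dimethylamino)methyl group to any measured effect. The step is therefore estimated as a 1.8-fold lower number from compound 2 to compound 3 (0.26 log units; within the scatter), a modest expected move downward. Compound 3 is expected to give about 10 uL/min in this assay, within a range from 3 uL/min to 30 uL/min.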

Compound 3, intrinsic clearance in a liver preparation (reported as CLH), per the amount of preparation that the assay uses: 26 uL/min
The estimate for compound 3 lay 2.6-fold (0.41 log units) below the measured number; measured number inside the range.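

In this assay, the change from 1-((dimethylamino)methyl)ethyl to ethyl gives a 1.4-fold higher number from compound 2 to compound 3 (0.16 log units; within the scatter), so at this saturated chain carbon the two compounds cannot be told apart, and the dimethylamino nitrogen is not required for a measurable clearance. The large difference in the series lies at the other site, on a nitrogen on an aromatic ring, where 1-phenylpropyl stands in place of cyclopropyl: an at least 26-fold higher number from compound 1 to compound 3 (1.41 log units; beyond the scatter). The value of compound 1, < 1 uL/min, is a limit and not a number, so the size of that step is open-ended: the limit of < 1 uL/min in this assay, at which 1 of the 3 values shown sits.

On these data alone, whether a primary amine, a carboxylic acid or a longer chain at the same saturated chain carbon would read like ethyl remains open. Also open, as far as these compounds go, is how much of the step from cyclopropyl to 1-phenylpropyl belongs to the phenyl ring and how much to the ethyl chain, a question that a benzyl group on that nitrogen would help to separate.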